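Swapping the Aryl Group on the Amide Carbonyl

The source may hold more compounds than are shown below. What is called first, only, known or untested is meant among the compounds shown, and "the series" means these compounds.

Measured compounds:
- compound 1, `O=C(Nc1cccc(-c2oc3cc(-c4ccc(F)cc4)ccc3c(=O)c2O)c1)c1ccccc1F`, in a functional assay on HCC1937 cells (Homo sapiens) for antiproliferative activity, read by CCK-8 assay, with a stated time of 72 h (on this read-out higher numbers stand for weaker inhibition and lower numbers for stronger inhibition), compound 1 gives 10800 nM
- compound 2, `COc1ccccc1C(=O)Nc1cccc(-c2oc3cc(-c4ccc(F)cc4)ccc3c(=O)c2O)c1`, compound 2 gives 9050 nM
- compound 3, `Cc1cccc(C(=O)Nc2cccc(-c3oc4cc(-c5ccc(F)cc5)ccc4c(=O)c3O)c2)c1`, compound 3 gives 8030 nM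

All three compounds share one core and differ only in the aryl group attached to the amide carbonyl. Compound 1, carrying the 2-fluorophenyl group, shows the highest number of the three, but its neighbours sit close: a 1.2-fold lower number from compound 1 to compound 2 (0.08 log units; within the scatter) and a 1.3-fold lower number from compound 1 to compound 3 (0.13 log units; within the scatter) are both within the scatter, as is a 1.1-fold lower number from compound 2 to compound 3 (0.05 log units; within the scatter). On the numbers shown, changing this aryl group has not moved the read-out beyond what repeated measurements of this kind would give.

Compound 4, `CCc1ccc(C(=O)Nc2cccc(-c3oc4cc(-c5ccc(F)cc5)ccc4c(=O)c3O)c2)cc1`, is not yet measured. Relative to compound 1 the change is 4-ethylphenyl in place of 2-fluorophenyl on a carbonyl carbon. Going by the values given here, the step from compound 1 to compound 3, which also places an alkyl group on the aryl ring, is the closest precedent, and it stayed within the scatter. The expected outcome in this assay is therefore a number near that of compound 1, perhaps slightly lower in line with compound 3, but not a step beyond the scatter.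

Compound 4 is estimated at 8500 nM, with a range from 4000 nM to 18000 nM. This estimate means a step of a 1.3-fold lower number from compound 1 to compound 4 (0.10 log units; within the scatter).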

Compound 4, half-maximal inhibitory concentration: 13200 nM
Estimate against measurement, compound 4: 1.6-fold (0.19 log units) below; the range from low to high includes it.
By their numbers in this assay, from the lowest: compounds 3, 2, 1 and 4 (each within the scatter of the next).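

In this assay the 4-ethylphenyl group on the carbonyl carbon gives a 1.2-fold higher number from compound 1 to compound 4 (0.09 log units; within the scatter) and a 1.5-fold higher number from compound 2 to compound 4 (0.16 log units; within the scatter) and also a 1.6-fold higher number from compound 3 to compound 4 (0.22 log units; within the scatter) when set against the three earlier groups. The earlier compounds shown here carried only 2-fluorophenyl, 2-methoxyphenyl and 3-methylphenyl at this place, so compound 4 widens the set to an ethyl-bearing ring, yet all four compounds remain within the scatter of one another and no aryl group stands apart from the others. Nothing measured here offers an explanation for why the numbers stay so close together.

Going by these compounds, all four groups are substituted phenyl rings, so it remains open whether a ring carrying an amine or a carboxylic acid, or one bearing a longer chain such as hexyl, would move the number beyond the scatter. On these data alone, it is also open whether a plain phenyl or a saturated ring such as cyclohexyl at this carbonyl carbon would give a value that differs clearly from those of these four compounds.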